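Furan-2-yl for phenyl in a level series

The compounds below may be only part of what the source reports. "The series", "measured", "known", "first", "only" and "open" are said of these compounds alone.

Compound 1 `CCCCn1cc(C(=O)NCc2ccc([N+](=O)[O-])cc2)c(=O)c2cc(F)c(N3CCC(C(N)=O)CC3)cc21`, compound 2 `CCCCn1cc(C(=O)NCc2ccc(OC)cc2)c(=O)c2cc(F)c(N3CCC(C(N)=O)CC3)cc21` and compound 3 `CCCCn1cc(C(=O)NCc2ccccc2)c(=O)c2cc(F)c(N3CCC(C(N)=O)CC3)cc21` differ only by nitro, methoxy or hydrogen on an aromatic carbon. In a physicochemical assay for lipophilicity, read by HPLC (a lower number here means a more polar compound, a higher number a more lipophilic compound), compound 1 gives 2.4, compound 2 gives 2.4 and compound 3 gives 2.4, so compound 3 stands level with both. Compound 4 `CCCCn1cc(C(=O)NCc2ccco2)c(=O)c2cc(F)c(N3CCC(C(N)=O)CC3)cc21` carries furan-2-yl in place of phenyl on a saturated chain carbon bound to an amide-type nitrogen. The closest evidence is no change at the digits printed from compound 1 to compound 3 (within the scatter) and no change at the digits printed from compound 2 to compound 3 (within the scatter), both within the scatter. Neither replaces the phenyl itself, so they guide only loosely. The expected step in this assay is a number 0.20 log units lower from compound 3 to compound 4 (within the scatter), a slight downward lean not expected to exceed the scatter. For compound 4 the estimate is 2.2, with an expected range of 1.9 to 2.5.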

Compound 4, partition coefficient: 2.4
Beside the measured number, compound 4's estimate is 0.20 log units below it, within the range that was stated.
By their numbers in this assay, from the lowest: compounds 1, 2, 3 and 4 (each within the scatter of the next).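

In this assay the change now reaches the ring itself, not only a group on it: no change at the digits printed from compound 3 to compound 4 (within the scatter), with a five-membered aromatic ring holding one oxygen replacing the six-membered carbon ring. The other two swaps read alike, no change at the digits printed from compound 2 to compound 4 (within the scatter) and no change at the digits printed from compound 1 to compound 4 (within the scatter), so at this position neither ring size nor the added hydrogen-bond acceptor gives a readable step. Nothing available here explains this result.

The compounds shown leave open whether an amine or a carboxylic acid in place of the ring would also stay level with these four.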